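The compounds below may be only part of what the source reports. "The series", "measured", "known", "first", "only" and "open" are said of these compounds alone.

In a functional assay on MV4-11 cells (Homo sapiens) for inhibition, read by resazurin assay, with a stated time of 72 h (on this read-out higher numbers stand for weaker inhibition of growth and lower numbers for stronger inhibition of growth), compound 1 (`O=C1NCCC12CCN(c1c(Cl)cncc1-c1cccs1)CC2`) gives 480 nM and compound 2 (`O=C1NCCC12CCN(c1c(Cl)cncc1-c1ccc(Cl)s1)CC2`) gives 560 nM and a 1.2-fold higher number from compound 1 to compound 2 (0.07 log units; within the scatter) comes with chloro in place of hydrogen on an aromatic carbon. Compound 3 (`Cn1cccc1-c1cncc(Cl)c1N1CCC2(CCNC2=O)CC1`) gives 900 nM and sits within the scatter of both, so the three values carry no order.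

The next change leads to compound 4 (`O=Cc1sccc1-c1cncc(Cl)c1N1CCC2(CCNC2=O)CC1`) and is 2-formylthiophen-3-yl in place of 1-methyl-1H-pyrrol-2-yl on an aromatic carbon with 2-formylthiophen-3-yl in place of 1-methyl-1H-pyrrol-2-yl on an aromatic carbon. For the measured compounds named here, no measured compound carries the 2-formylthiophen-3-yl group, so the data test this group only indirectly. The swaps already measured at this place are small: a 1.9-fold higher number from compound 1 to compound 3 (0.27 log units; within the scatter) and a 1.6-fold higher number from compound 2 to compound 3 (0.21 log units; within the scatter) both stay within the scatter.

On that basis, no shift beyond the scatter is expected in this assay and the expected step is a 1.1-fold lower number from compound 3 to compound 4 (0.05 log units; within the scatter) in no firm direction. The estimate for compound 4 is 800 nM (expected range 250 nM to 2500 nM).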

Compound 4, concentration for 50% growth inhibition: 28700 nM
Estimate against measurement, compound 4: 36-fold (1.55 log units) below; the whole stated range lies below it.
By their numbers in this assay, from the lowest: compounds 1, 2 and 3 (each within the scatter of the next); then compound 4.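

In this assay this position proves far less tolerant than the earlier swaps suggested, since 2-formylthiophen-3-yl in place of 1-methyl-1H-pyrrol-2-yl gives a 32-fold higher number from compound 3 to compound 4 (1.50 log units; beyond the scatter) as a step beyond the scatter. The same group gives a 51-fold higher number from compound 2 to compound 4 (1.71 log units; beyond the scatter) when it replaces 5-chlorothiophen-2-yl and a 60-fold higher number from compound 1 to compound 4 (1.78 log units; beyond the scatter) when it replaces thiophen-2-yl, so the large step appears against all three earlier groups and does not depend on the one leaving. No measurement at hand explains the size of this step.

The compounds shown do not separate the formyl group from the thiophen-3-yl attachment, as both enter together. An unsubstituted thiophen-3-yl would test the attachment alone, while a hydroxymethyl, a carboxylic acid or an aminomethyl group in place of the formyl would test the substituent.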